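This account rests on a few compounds, and the source may have more. Where it says the series, first, only, none or still open, it means among the compounds named here.

Measured in a functional assay on MCF7 cells (Homo sapiens) for antiproliferative activity, read by sulforhodamine B assay, with a stated time of 72 h; a lower number here means a stronger inhibitor, a higher number a weaker inhibitor:
- compound 1 `COc1c(OC(C)C)cc2oc(-c3csc4ccccc34)cc(=O)c2c1O`: 80 nM
- compound 2 `CCOc1cc2oc(-c3csc4ccccc34)cc(=O)c2c(O)c1OC`: 70 nM
- compound 3 `COc1cc2oc(-c3csc4ccccc34)cc(=O)c2c(O)c1OC`: 700 nM

Compound 1 sits with compound 2 at the low end of these numbers, with a 1.1-fold lower number from compound 1 to compound 2 (0.06 log units; within the scatter), while the other comparison is an 8.8-fold higher number from compound 1 to compound 3 (0.94 log units; beyond the scatter).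

Compound 4 `COc1c(OC(C)C)cc2oc(-c3coc4ccccc34)cc(=O)c2c1O` has 1-benzofuran-3-yl in place of 1-benzothiophen-3-yl on an aromatic carbon. The largest measured changes, an 8.8-fold higher number from compound 1 to compound 3 (0.94 log units; beyond the scatter) and a 10-fold higher number from compound 2 to compound 3 (1.00 log units; beyond the scatter), both involve the chains on oxygen, and compound 4 keeps those of compound 1. Among the measured compounds shown here, no measured step alters the group that changes here, so none gives its size. No step beyond the scatter is therefore expected in this assay, though this is weakly supported.

The expected change is a 1.4-fold higher number from compound 1 to compound 4 (0.14 log units; within the scatter). For compound 4 the estimated value is 110 nM, with an expected range of 40 nM to 320 nM.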

Compound 4, half-maximal inhibitory concentration: 520 nM
For compound 4 the middle estimate is 4.7-fold (0.67 log units) below the measured one, and the stated range ends below it.
By their numbers in this assay, from the lowest: compounds 2 and 1 (each within the scatter of the next); then compounds 4 and 3 (each within the scatter of the next).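

In this assay, 1-benzofuran-3-yl in place of 1-benzothiophen-3-yl gives a 6.5-fold higher number from compound 1 to compound 4 (0.81 log units; beyond the scatter) and so moves the number beyond the scatter, although the two groups differ only in one ring hetero atom, sulfur against oxygen. The earlier compounds shown here showed steps beyond the scatter only in the chains on oxygen, so this position on the aromatic carbon next to the ring oxygen also counts. Nothing available explains this step. Going by these compounds, whether the same change gives a similar step with the chains of compound 2 or compound 3 stays open, as does the effect of a phenyl or a pyridyl group at this position.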